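This account rests on a few compounds, and the source may have more. Where it says the series, first, only, none or still open, it means among the compounds named here.

The numbers below come from a functional assay on WiDr cells (Homo sapiens) for inhibition; on this read-out lower numbers stand for stronger inhibition and higher numbers for weaker inhibition.

Compound 1, `N#CC1CN1C(=O)Nc1ccc(Cl)cc1Cl`, gives 1900 nM.
Compound 2, `N#CC1CN1C(=O)Nc1ccc(Cl)c(Cl)c1`, gives 14000 nM.
Compound 3, `CCCCNC(=O)N1CC1C#N`, gives 18000 nM.

Among the measured compounds shown here, all three compounds share the same core, the one seen in compound 3, and differ only in what hangs on the amide-type nitrogen. Of the three numbers in this assay, compound 3 stands highest. Its nearest neighbour is compound 2, whose number lies within the scatter of repeated measurements, so no order between compound 2 and compound 3 can be read from the data. Compound 1 lies furthest away, and that gap is beyond the scatter.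

Compound 4, `CNC(=O)N1CC1C#N`, has not yet been measured. It differs from compound 3 in one place: hydrogen in place of propyl on a saturated chain carbon bound to an amide-type nitrogen. Cut one bond further out, the chain goes from butyl to methyl. For the measured compounds named here, no pair of measured compounds shows this kind of change, so there is no measured step to lean on. In this assay a small step toward a higher number is expected, perhaps none beyond the scatter. Compound 4 is therefore estimated at 30000 nM, with a range from 10000 nM to 90000 nM. That estimate means an expected step of a 1.7-fold higher number from compound 3 to compound 4 (0.22 log units; within the scatter).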

Compound 4, half-maximal inhibitory concentration: 23000 nM
For compound 4 the middle estimate is 1.3-fold (0.12 log units) above the measured one; the range from low to high includes it.
By their numbers in this assay, from the lowest: compound 1; then compounds 2, 3 and 4 (each within the scatter of the next).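

In this assay, among the compounds shown here, the cut from butyl to methyl gives a 1.3-fold higher number from compound 3 to compound 4 (0.11 log units; within the scatter) and this is the first measured step on this chain. Removing propyl and leaving hydrogen at this saturated chain carbon bound to an amide-type nitrogen therefore produces no change that can be told apart from the normal spread of repeated measurements, so in this pair the length of the chain does not visibly shift the number, and the short methyl chain serves as well as the butyl chain. No supporting measurement is available to explain this result.

The pair covers only two simple saturated chains, so it cannot say whether this flat behaviour extends beyond butyl and methyl to a longer chain such as octyl or to a ring such as cyclohexyl. It also leaves open what happens to the number when a chain of this kind ends in an amine or a carboxylic acid, groups that differ from a plain carbon chain in their atoms.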